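The source may report more compounds than this note shows. Statements on the series, on what has been measured and on what is new or still open speak of the compounds shown alone.

Measured so far:
- compound 1, `CS(=O)(=O)Nc1ccccc1CCC(SCCC(=O)O)c1cccc(OCc2ccc3ccc(Cl)cc3n2)c1`: 131 mL/min/kg
- compound 2, `CCC(CSC(CCc1ccccc1S(C)(=O)=O)c1cccc(OCc2ccc3ccc(Cl)cc3n2)c1)C(=O)O`: 35 mL/min/kg

Both values come from an in vivo ADME assay on the whole organism (plasma) for pharmacokinetics, with Rattus norvegicus as the target, at a dose of 5 mg/kg by the intravenous route; a higher number here means faster removal of the compound, a lower number slower removal. Compound 2 has the lower of the two numbers; compound 1 sits higher, and the gap between them is beyond the usual scatter, so compound 2 is the slower-cleared of the pair on the numbers in hand.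

Compound 3, `CCC(CSC(CCc1ccccc1-c1nnnn1C)c1cccc(OCc2ccc3ccc(Cl)cc3n2)c1)C(=O)O`, has not been measured. It is built from compound 2 by the following change:
1-methyl-1H-tetrazol-5-yl in place of methylsulfonyl on an aromatic carbon

Among the measured compounds shown here, no measured pair in this set carries that change, so there is no step to lean on; the only anchor is the value of compound 2 in this assay, which is 35 mL/min/kg. On that basis compound 3 is expected to stay close to its parent, with a step of a 1.3-fold higher number from compound 2 to compound 3 (0.11 log units; within the scatter), slightly upward but within the scatter rather than beyond it. The estimate for compound 3 in this assay is therefore 45 mL/min/kg, with a plausible range from 20 mL/min/kg to 110 mL/min/kg.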

Compound 3, clearance: 18 mL/min/kg
The estimate for compound 3 lay 2.5-fold (0.40 log units) above the measured number, and the stated range ends above it.
By their numbers in this assay, from the lowest: compounds 3 and 2 (each within the scatter of the next); then compound 1.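

In this assay, among the compounds shown here, replacing methylsulfonyl with 1-methyl-1H-tetrazol-5-yl on an aromatic carbon, ortho to a large group, gives a 1.9-fold lower number from compound 2 to compound 3 (0.29 log units; within the scatter), the first reading of a change in one place. At this place, then, a group of no ring and a five-membered aromatic ring with 4 hetero atoms are not separated by this read-out, even though the entering group carries more heavy atoms and more hydrogen-bond acceptors than the one it replaces. No measurement in hand offers an explanation for this result.

As far as these compounds go, whether the same holds for other groups at this place, such as a nitrile, a primary carboxamide or a tetrazole without the methyl group, remains open, as does how a group on this ring would read in a compound with the shorter acid chain of compound 1. The effect of changing the ethyl branch on the acid chain, or of replacing the carboxylic acid itself, also stays unresolved with the compounds shown.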